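The compounds below may be only part of what the source reports. "The series", "measured", "known", "first", "only" and "open" are said of these compounds alone.

Measured compounds in a functional assay on U-87MG ATCC cells (Homo sapiens) for antiproliferative activity, read by MTT assay, with a stated time of 48 h; a higher number here means a weaker inhibitor, a lower number a stronger inhibitor:
- compound 1, `O=C(/C=C\Nc1ccc(F)cc1)c1cn(-c2ccccc2)nc1-c1ccccc1`: 10200 nM
- compound 2, `O=C(/C=C\Nc1ccc(F)cc1)c1cn(-c2ccccc2)nc1-c1ccc(F)cc1`: 18200 nM

For the measured compounds named here, compound 2 holds the higher of the two numbers, but the only step within the pair, a 1.8-fold higher number from compound 1 to compound 2 (0.25 log units; within the scatter), lies within the scatter, so the two compounds are not ordered on these data.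

Compound 3, `O=C(/C=C\Nc1ccc(F)cc1)c1cn(-c2ccccc2)nc1-c1ccc(Cl)cc1`, differs from compound 2 by chloro in place of fluoro on an aromatic carbon.

Going by the values given here, no measured step covers a chloro-for-fluoro exchange. Among the compounds with values here, the one step that touches this position, a 1.8-fold higher number from compound 1 to compound 2 (0.25 log units; within the scatter), is within the scatter, which suggests that a single halogen at this place leaves the number roughly where it is. On that footing the expected step from compound 2 to compound 3 in this assay is a 1.1-fold lower number from compound 2 to compound 3 (0.06 log units; within the scatter), with no direction claimed beyond the scatter.

Compound 3 is therefore estimated at 16000 nM in this assay, with an expected range from 5000 nM to 50000 nM.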

Compound 3, half-maximal inhibitory concentration: 17900 nM
For compound 3 the middle estimate is 1.1-fold (0.05 log units) below the measured one; the measured number falls inside the stated range.
By their numbers in this assay, from the lowest: compounds 1, 3 and 2 (each within the scatter of the next).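

In this assay 4-chlorophenyl in place of 4-fluorophenyl gives a 1.0-fold lower number from compound 2 to compound 3 (0.01 log units; within the scatter) and so adds a direct exchange of one halogen for the other, which leaves no readable difference at this place. Chloro in place of hydrogen at the same carbon gives a 1.8-fold higher number from compound 1 to compound 3 (0.24 log units; within the scatter) and so, like fluoro, cannot be told apart from the hydrogen of compound 1, which leaves hydrogen, fluoro and chloro unordered at this place. No evidence is available that bears on this result.

On these data alone, whether the number responds at all to a group other than a halogen here, such as an amine, a carboxylic acid or a longer chain, remains open. As far as these compounds go, the rest of the shared core is the same in all three compounds, so its bearing on the number also remains open.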